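Fused core series: methoxy to methylsulfanyl swap

The source may report more compounds than this note shows. Statements on the series, on what has been measured and on what is new or still open speak of the compounds shown alone.

Measured so far:
compound 1, `COc1cc(SC)nc(NC(=S)NC(=O)c2c(-c3ccc(Cl)cc3Cl)noc2C)n1`, gives -8.31%
compound 2, `COc1cc(OC)n2s/c(=N\C(=O)c3c(-c4ccc(Cl)cc4Cl)noc3C)nc2n1`, gives 28.9%

In a functional assay on the whole organism for inhibition, with Chenopodium ficifolium as the target, with a stated time of 72 h, tested at 10 mg/L (a lower number here means less inhibition of growth, a higher number more inhibition of growth at the concentration tested), compound 2 holds the highest of the two numbers; compound 1 sits lower by a margin beyond the scatter. Going by the values given here, the two compounds differ in more than one place, so no single step can be read from them, only that the fused core of compound 2 is the one that shows inhibition.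

Compound 3, `COc1cc(SC)nc2n/c(=N/C(=O)c3c(-c4ccc(Cl)cc4Cl)noc3C)sn12`, keeps the fused core of compound 2 and differs from it by methylsulfanyl in place of methoxy on an aromatic carbon. Among the compounds with values here, no pair of measured compounds isolates this change. Within the data shown here, the expectation in this assay is therefore a small step, downward or none beyond the scatter, since the only measured compound carrying methylsulfanyl, compound 1, gives -8.31% on a different core. Compound 3 is estimated at 22%, range 0% to 45%. The expected step of a number 6.9 percentage points lower from compound 2 to compound 3 (within the scatter) stays within the usual scatter.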

Compound 3, percent growth inhibition at one concentration: 23.8%
Estimate against measurement, compound 3: 1.8 percentage points below, within the range that was stated.
By their numbers in this assay, from the lowest: compound 1; then compounds 3 and 2 (each within the scatter of the next).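

In this assay, going by these compounds alone, methylsulfanyl in place of methoxy on the aromatic carbon next to the ring nitrogen gives a number 5.1 percentage points lower from compound 2 to compound 3 (within the scatter), the only step so far that isolates a single place. Within the data shown here, on this core, the position therefore accepts either group without a change that can be separated from the scatter, which the earlier compounds, differing in more than one place, could not show. Nothing measured bears on why the two groups read alike here.

From the compounds shown here alone, it remains open whether this tolerance extends beyond these two groups, for example to an amine such as dimethylamino, to a chlorine atom, or to a longer chain such as butylsulfanyl, and whether the same exchange at the remaining methoxy group would read the same way. Going by these compounds, with only percent growth inhibition at one concentration available, it is also open whether compound 2 and compound 3 would remain within the scatter of each other at other concentrations.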